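Piperazine substitution on the shared core, compound 2 to compound 3

A few compounds are considered here, and "the series" means these few. Any claim that something is new, unique, unknown or untested is made for them only; others in the source may bear on it.

Compound 2 `CN(C[C@H]1Cc2c(cccc2N2CCN(C3COC3)CC2)CN1)[C@H]1CCCc2cccnc21` gives 381 nM in a functional assay on CCRF-CEM cells for antagonist activity at C-X-C chemokine receptor type 4 (Homo sapiens), read by calcium flux, with stated times of 25 min and 90 s (on this read-out lower numbers stand for stronger inhibition and higher numbers for weaker inhibition), the higher of the two numbers in hand. Within the data shown here, compound 1 `c1cnc2c(c1)CCC[C@@H]2N(CC1CC1)C[C@H]1Cc2c(cccc2N2CCNCC2)CN1`, which differs from it in several places, gives 26.7 nM in this assay; no single step joins the two, so the pair shows only that compound 1 sits at the lower number and compound 2 at the higher. Compound 3 `C[C@@H]1CN(c2cccc3c2C[C@H](CN(C)[C@H]2CCCc4cccnc42)NC3)C[C@H](C)N1` is not yet measured. It differs from compound 2 as follows: 3,5-dimethylpiperazin-1-yl in place of 4-(oxetan-3-yl)piperazin-1-yl on an aromatic carbon. The entering group carries a hydrogen-bond donor, as the piperazin-1-yl of compound 1 does. A move from compound 2 toward a lower number, beyond the scatter, is expected, though the two measured compounds differ in more than this one place, so the size is uncertain. The expected step is a 4.2-fold lower number from compound 2 to compound 3 (0.63 log units; beyond the scatter). Compound 3 is expected to give 90 nM in this assay, within 25 nM to 320 nM.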

Compound 3, half-maximal inhibitory concentration: 61 nM
The estimate for compound 3 lay 1.5-fold (0.17 log units) above the measured number, and the stated range covers the measured number.
By their numbers in this assay, from the lowest: compound 1; then compound 3; then compound 2.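

Replacing 4-(oxetan-3-yl)piperazin-1-yl with 3,5-dimethylpiperazin-1-yl on this aromatic carbon gives, in this assay, a 6.2-fold lower number from compound 2 to compound 3 (0.80 log units; beyond the scatter). Among these compounds, this is the first single-place step, and it shows that the read-out responds to the group at this position while the rest of compound 2 stays unchanged. The change alters several features at once, as the oxetane ring leaves while a hydrogen-bond donor, methyl groups and defined stereocentres enter, and no measurement in hand ties the shift to any one of them or explains it.

Still open, on these data alone, is how much of the step follows the free ring nitrogen and how much the methyl groups. A morpholin-4-yl, a 4-methylpiperazin-1-yl or a 3-methylpiperazin-1-yl group at this position would help separate these contributions.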